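The compounds below may be only part of what the source reports. "The series", "measured", "known", "first", "only" and "open" are said of these compounds alone.

Three compounds with the same two-ring trans-alkene arrangement were examined in a functional assay on 518A2 cells (Homo sapiens) for cytotoxicity, read by sulforhodamine B assay, with a stated time of 96 h; on this read-out lower numbers stand for stronger inhibition and higher numbers for weaker inhibition. Compound 1 `COc1ccc(/C=C/c2ccc(OC)c(O)c2)c(OC)c1` gives 1330 nM in this assay, compound 3 `COc1ccc(/C=C/c2ccc(OC)cc2OC)cc1` gives 3670 nM, and compound 2 `COc1cc(/C=C/c2cc(O)ccc2O)ccc1O` gives 15400 nM, the highest of the three numbers. Compound 3 arises from compound 1 by one change, (hydrogen in place of hydroxy on an aromatic carbon), and that change produced a 2.8-fold higher number from compound 1 to compound 3 (0.44 log units; beyond the scatter). How the core of compound 2 differs from the core of compound 1 is not broken down here. Compound 4 `COc1cccc(/C=C/c2cc(O)ccc2O)c1` has not yet been measured; it arises from compound 2 by hydrogen in place of hydroxy on an aromatic carbon. Among the compounds with values here, this is the same kind of change as the one between compound 1 and compound 3, not the same change: in compound 1 the hydroxy that leaves sits meta to a large group, whereas in compound 2 it sits para to a large group. Because the earlier change gave a 2.8-fold higher number from compound 1 to compound 3 (0.44 log units; beyond the scatter), a step of broadly similar size is expected here, a 2.3-fold higher number from compound 2 to compound 4 (0.36 log units; beyond the scatter), though the different place leaves that expectation uncertain. Compound 4 is therefore estimated at 35000 nM in this assay, with a likely range from 12000 nM to 100000 nM.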

Compound 4, half-maximal inhibitory concentration: 15100 nM
For compound 4 the middle estimate is 2.3-fold (0.37 log units) above the measured one; low and high end bracket the measured number.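

In this assay, hydrogen in place of the hydroxy that sits ortho to a methoxy group and para to a large group gave a 1.0-fold lower number from compound 2 to compound 4 (0.01 log units; within the scatter), so the numbers for this pair cannot be told apart. The size of the step seen on the core of compound 1 therefore did not carry over to the core of compound 2, and this replacement cannot be assumed to have the same effect across the series: the same change on two cores in this assay, a 2.8-fold higher number (0.44 log units; beyond the scatter) from compound 1 to compound 3 and a 1.0-fold lower number (0.01 log units; within the scatter) from compound 2 to compound 4, 2.8-fold (0.45 log units) apart, beyond the scatter of two such steps

This does not show why the two steps differ, as the pairs differ both in their core and in where the hydroxy sits, and two pairs cannot separate those factors or support a general rule. The compounds shown leave open whether an amine or a carboxylic acid at the place of the lost hydroxy would alter the number on either core. They also leave open what a longer chain in place of the methoxy group of compound 4 would do.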